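From Ethoxy to Phenyl on a Carbonyl Carbon

The compounds below may be only part of what the source reports. "The series", "measured", "known", "first", "only" and "open" are said of these compounds alone.

Measured in a functional assay on Raji cells (Homo sapiens) for cytotoxicity, with a stated time of 72 h; a higher number here means a weaker inhibitor, a lower number a stronger inhibitor:
- Compound 1 `CCOC(=O)/C=C/C=C/C=C/C=C/c1ccc[nH]1`: 4090 nM
- Compound 2 `CCOC(=O)/C=C/C=C/C=C/C=C/c1cccn1C`: > 10000 nM

For the measured compounds named here, compound 1 holds the only true number so far, 4090 nM. Compound 2 reads > 10000 nM, which is a limit of the assay and not a number. Compound 3 `O=C(/C=C/C=C/C=C/C=C/c1ccc[nH]1)c1ccccc1` has not yet been measured in this assay. It keeps the core of compound 1 but carries phenyl in place of ethoxy on a carbonyl carbon.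

Going by the values given here, the only measured step is an at least 2.4-fold higher number from compound 1 to compound 2 (0.38 log units; beyond the scatter), beyond the scatter, with methyl in place of hydrogen on an aromatic nitrogen. Its size is open-ended, set by the limit of > 10000 nM in this assay, at which 1 of the 2 values shown sits. It shows that one small change can matter, but it sits elsewhere on the molecule, so it gives no direction for this change. Expected here is a 1.0-fold lower number from compound 1 to compound 3 (0.01 log units; within the scatter), with no clear step beyond the scatter. Compound 3 is estimated at 4000 nM, with an expected range from 1000 nM to 10000 nM.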

Compound 3, half-maximal inhibitory concentration: 5990 nM
Compound 3: the middle estimate sits 1.5-fold (0.18 log units) below what was measured; the range from low to high includes it.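

In this assay, phenyl in place of ethoxy on a carbonyl carbon gives a 1.5-fold higher number from compound 1 to compound 3 (0.17 log units; within the scatter), so this position accepts a six-membered aromatic ring of carbon in place of a small open group, and the hydrogen-bond acceptor of the ethoxy group is lost, without a step beyond the scatter. Unlike the change on the aromatic nitrogen, this change has a size that can be read in full, and it shows that not every change to this molecule separates two compounds clearly. Compound 2 still carries a limit and not a number: the limit of > 10000 nM in this assay, at which 1 of the 3 values shown sits.

As far as these compounds go, whether an amine or a hydroxyl group on this carbonyl carbon would give a step beyond the scatter remains open. A single swap also cannot show whether a longer chain or a substituted phenyl here would behave the same way.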